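Adding a Pentafluoro Sulfur Group to a Tetrazole Hydroxamate

The compounds below may be only part of what the source reports. "The series", "measured", "known", "first", "only" and "open" are said of these compounds alone.

For the measured compounds named here, compound 2 `O=C(NO)c1ccc(Cn2nnc(-c3ccccc3)n2)cc1` gives the lower of the two numbers measured so far in an assay on Sf9 cells for inhibition of protein deacetylase HDAC6 (Homo sapiens), read by fluorescence; on this read-out lower numbers stand for stronger inhibition and higher numbers for weaker inhibition: compound 2 gives 3 nM, while compound 1 `O=C(O)c1cccc(-c2nnn(Cc3ccc(C(=O)NO)cc3)n2)c1` gives 12 nM. The two differ in a carboxy group on a ring of the shared core, and taking that group away is the step of a 4.0-fold lower number from compound 1 to compound 2 (0.60 log units; beyond the scatter).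

Compound 3 `O=C(NO)c1ccc(Cn2nnc(-c3cccc(S(F)(F)(F)(F)F)c3)n2)cc1` carries a group of 6 heavy atoms (5 fluorine, 1 sulfur; no ring) in place of a hydrogen atom, on an aromatic carbon of a six-membered aromatic ring of carbon only, meta to a large group (a group of 6 heavy atoms (5 fluorine, 1 sulfur; no ring) in place of a hydrogen atom, on an aromatic carbon). Going by the values given here, only the step from compound 1 to compound 2 bears on this change, and it shows that a group at this place can shift the number beyond the scatter, though a different group enters here. The expected step in this assay is a 1.7-fold higher number from compound 2 to compound 3 (0.22 log units; within the scatter). Compound 3 is expected to give about 5 nM, estimated between 1.5 nM and 20 nM.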

Compound 3, half-maximal inhibitory concentration: 26 nM
Compound 3: middle estimate off by 5.2-fold (0.72 log units), on the low side; measured number outside the range, above it.
By their numbers in this assay, from the lowest: compound 2; then compound 1; then compound 3.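

In this assay, this aromatic carbon proves sensitive to what it carries: putting the pentafluoro sulfur group in place of hydrogen is an 8.7-fold higher number from compound 2 to compound 3 (0.94 log units; beyond the scatter), a larger step than removing the carboxy group had suggested. Exchanging the carboxy group for the pentafluoro sulfur group at this place is a 2.2-fold higher number from compound 1 to compound 3 (0.34 log units; beyond the scatter), so among these three compounds, the ring with hydrogen here gives the lowest number, and the two groups also differ from each other. Nothing measured here explains why the new group raises the number.

As far as these compounds go, what a fluorine atom, a methyl group or an amine would do at this place remains open. So does whether the pentafluoro sulfur group would give a similar step on a different carbon of the ring.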